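The source may report more compounds than this note shows. Statements on the series, on what has been measured and on what is new or still open speak of the compounds shown alone.

Compounds measured in a functional assay on HT-29 cells (Homo sapiens) for antiproliferative activity, read by MTT assay, with a stated time of 72 h; a higher number here means a weaker inhibitor, a lower number a stronger inhibitor:
- compound 1 `C=CC(=O)N(Cc1cc(C)no1)c1nc(-c2ccccc2OC)cs1`: > 30000 nM
- compound 2 `C=CC(=O)N(Cc1cc(C)no1)c1nc(-c2ccc(Cl)cc2O)cs1`: > 30000 nM

Compound 2 `C=CC(=O)N(Cc1cc(C)no1)c1nc(-c2ccc(Cl)cc2O)cs1` gives > 30000 nM, which is a limit and not a number. Compound 1 gives > 30000 nM, also a limit. So the measured set offers only (the limit of > 30000 nM in this assay, at which 2 of the 2 values shown sit).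

Compound 3 `C=CC(=O)N(Cc1cc(C)no1)c1nc(-c2ccc(F)cc2O)cs1` differs from compound 2 in one place: fluoro in place of chloro on an aromatic carbon. The new fluoro group sits meta to a hydroxy group and para to a large group.

For the measured compounds named here, the only measured step that bears on this is a step that the two limits leave unreadable from compound 1 to compound 2, so it supplies no size to carry over. No step beyond the scatter is therefore expected, and compound 3 will probably also report only a limit in this assay. The expected change is a number no higher from compound 2 to compound 3 (the limit leaves the size open). Compound 3 is estimated at 30000 nM, with an expected range from 12000 nM to 60000 nM.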

Compound 3, half-maximal inhibitory concentration: > 30000 nM
Compound 3 was reported as a limit (the forecaster's own chance of this, stated with the estimate: 75%); the middle value lies on the limit itself.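

In this assay compound 3 gives > 30000 nM, a limit and not a number, and the steps to it from compound 1 and compound 2 cannot be read. The compounds shown leave open what fluoro in place of chloro does to potency, and how potent any of the three is, because the set offers only this: the limit of > 30000 nM in this assay, at which 3 of the 3 values shown sit.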